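Methyl on the ring amine of compound 2

This account rests on a few compounds, and the source may have more. Where it says the series, first, only, none or still open, it means among the compounds named here.

Of the compounds shown here, two have numbers so far. In a functional assay on NCI-H1650 cells (Homo sapiens) for cytotoxicity, read by MTT assay, with a stated time of 72 h (a higher number here means a weaker inhibitor, a lower number a stronger inhibitor), compound 1 `COc1ccc(/C=C2\CNC/C(=C\c3ccc(OC)c(OC)c3)C2=O)cc1OC` gives 16700 nM and compound 2 `COc1cc(/C=C2\CNC/C(=C\c3cc(OC)c(OC)c(OC)c3)C2=O)cc(OC)c1OC` gives 4200 nM. Compound 2 thus stands lowest of the two, as the stronger inhibitor, and its gap to compound 1 lies beyond the usual scatter. The two differ in more than one place, so that gap cannot be assigned to any single group.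

The next step starts from compound 2. Compound 3 `COc1cc(/C=C2\CN(C)C/C(=C\c3cc(OC)c(OC)c(OC)c3)C2=O)cc(OC)c1OC` has methyl in place of hydrogen on an amine nitrogen in a ring, and the rest of the structure is unchanged. For the measured compounds named here, no measured pair shows this change, so the expectation rests only on the small size of the change and stays loose. In this assay, no shift beyond the scatter is expected, and neither direction can be firmly favoured. The estimated step is a 1.2-fold lower number from compound 2 to compound 3 (0.08 log units; within the scatter). Compound 3 is expected at 3500 nM, with an estimated range of 1200 nM to 10000 nM.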

Compound 3, half-maximal inhibitory concentration: 1500 nM
Compound 3: the middle estimate sits 2.3-fold (0.37 log units) above what was measured, and the stated range covers the measured number.
By their numbers in this assay, from the lowest: compound 3; then compound 2; then compound 1.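

For the compounds shown here, the pair compound 2 and compound 3 is the first that differs in one place, so the amine nitrogen in the six-membered non-aromatic ring can now be read on its own, which the gap between compound 1 and compound 2 did not allow. In this assay methyl in place of hydrogen at this nitrogen gives a 2.8-fold lower number from compound 2 to compound 3 (0.45 log units; beyond the scatter) and so the step is modest but beyond the scatter, with the number moving towards stronger inhibition. The hydrogen on this nitrogen is therefore not required for the activity seen here, and the position takes one added carbon without loss, although nothing at hand explains the size or direction of this step.

On these data alone, a single step sets no trend at this nitrogen, so it remains open whether a longer chain such as ethyl, a benzyl group or an acyl group such as acetyl would lower the number further, leave it unchanged or raise it. As far as these compounds go, it also remains open whether methyl on the same nitrogen of compound 1 would produce a step of similar size, which would show whether the effect carries over to the core with fewer methoxy groups.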